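The source may hold more compounds than are shown below. What is called first, only, known or untested is meant among the compounds shown, and "the series" means these compounds.

Compounds measured so far:
- compound 1 `COC(=O)CC1CCN(C[C@H]2CN(c3ccc(-n4cc(-c5ccccn5)cn4)c(F)c3)C(=O)O2)CC1`: 224 ug/mL
- compound 2 `COC(=O)NC[C@H]1CN(c2ccc(-n3cc(-c4ccccn4)cn3)c(F)c2)C(=O)O1`: 306 ug/mL
- compound 3 `NC(=O)[C@H]1CN(c2ccc(-n3cc(-c4ccccn4)cn3)c(F)c2)C(=O)O1`: 152 ug/mL

All three share one core and differ only in the group on a saturated ring carbon. In an ADME assay on HEK293-A cells (Homo sapiens) for cytotoxicity, read by MTT assay, with a stated time of 48 h (a lower number here means a stronger inhibitor, a higher number a weaker inhibitor), compound 1 gives 224 ug/mL, the second highest of the three numbers, but its neighbours sit close: a 1.4-fold higher number from compound 1 to compound 2 (0.14 log units; within the scatter) and a 1.5-fold lower number from compound 1 to compound 3 (0.17 log units; within the scatter), both within the scatter, as is a 2.0-fold lower number from compound 2 to compound 3 (0.30 log units; within the scatter). So far, then, swapping this side group has not moved the read-out beyond noise.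

Compound 4 `CONC(=O)[C@H]1CN(c2ccc(-n3cc(-c4ccccn4)cn3)c(F)c2)C(=O)O1` is the next change at the same place: methoxycarbamoyl in place of (4-((methoxycarbonyl)methyl)piperidin-1-yl)methyl on a saturated ring carbon. The entering group most resembles the carbamoyl of compound 3, which gave 152 ug/mL. Because a 1.5-fold lower number from compound 1 to compound 3 (0.17 log units; within the scatter) was within the scatter, no step beyond the scatter is expected here either, in this assay (a 1.1-fold lower number from compound 1 to compound 4 (0.05 log units; within the scatter) is the expected shift). Compound 4 is therefore estimated at 200 ug/mL, with a likely range from 100 ug/mL to 400 ug/mL.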

Compound 4, half-maximal inhibitory concentration: > 400 ug/mL
Compound 4: no number, only a limit (the forecaster's own chance of this, stated with the estimate: 20%); at least 2.0-fold (0.30 log units) between middle value and limit.
By their numbers in this assay, from the lowest: compounds 3, 1 and 2 (each within the scatter of the next). At a limit, above all of these: compound 4.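

In this assay compound 4 gives no number, only a limit: the limit of > 400 ug/mL in this assay, at which 1 of the 4 values shown sits. Methoxy in place of hydrogen on an amide-type nitrogen gives an at least 2.6-fold higher number from compound 3 to compound 4 (0.42 log units; beyond the scatter), the first step at this saturated ring carbon that lies beyond the scatter, so a single added methoxy moved the read-out where the earlier swaps of whole side groups had not. The other two steps, an at least 1.7-fold higher number from compound 1 to compound 4 (0.25 log units; that floor lies within the scatter) and an at least 1.3-fold higher number from compound 2 to compound 4 (0.11 log units; that floor lies within the scatter), have floors within the scatter, so they do not clearly separate compound 4 from compound 1 or compound 2.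

The compounds shown leave open how far above its limit compound 4 really lies. They also leave open whether a hydroxy or an ethoxy on that nitrogen, or a carboxylic acid at this ring carbon, would give a step of similar size.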